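The compounds below may be only part of what the source reports. "The series", "measured", "known", "first", "only" and "open" are said of these compounds alone.

Compound 1 `COC(=O)c1c(-c2cc3ccccc3oc2=O)nn(-c2cccc(C)c2)c1C(=O)OC` and compound 2 `COC(=O)c1c(-c2cc3ccccc3oc2=O)nn(-c2cccc(Cl)c2)c1C(=O)OC` share one core and differ only by chloro in place of methyl on an aromatic carbon. In a functional assay on DU-145 cells (Homo sapiens) for cytotoxicity, read by MTT assay, with a stated time of 48 h (on this read-out higher numbers stand for weaker inhibition and lower numbers for stronger inhibition), compound 1 gives 35000 nM, and in this assay compound 2 gives 32000 nM, so that the step of a 1.1-fold lower number from compound 1 to compound 2 (0.04 log units; within the scatter) lies within the scatter of repeated runs. Compound 3 `CCOC(=O)c1c(-c2cc3cc(OC)ccc3oc2=O)nn(-c2cccc(C)c2)c1C(=O)OCC` is built on a different core; how the core of compound 1 and the core of compound 3 differ is not broken down here. In this assay compound 3 gives 31000 nM, a number within the scatter of the values of compound 1 and compound 2. Compound 4 `CCOC(=O)c1c(-c2cc3cc(OC)ccc3oc2=O)nn(-c2cccc(Cl)c2)c1C(=O)OCC` is related to compound 3 by chloro in place of methyl on an aromatic carbon, which is the same change that turns compound 1 into compound 2. That single measured pair is all the basis there is, and because the pair of compound 1 and compound 2 stayed within the scatter, the step of a 1.0-fold lower number from compound 3 to compound 4 (0.01 log units; within the scatter) is expected to be just as small. Compound 4 is therefore estimated to give 30000 nM in this assay, with a range from 15000 nM to 60000 nM.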

Compound 4, half-maximal inhibitory concentration: 29000 nM
Estimate against measurement, compound 4: 1.0-fold (0.01 log units) above, and the stated range covers the measured number.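

In this assay, 3-chlorophenyl in place of 3-methylphenyl gives a 1.1-fold lower number from compound 3 to compound 4 (0.03 log units; within the scatter), so on the core of compound 3 the change again stays within the scatter. Set beside the earlier case, the two steps agree: the same change on two cores in this assay, a 1.1-fold lower number (0.04 log units; within the scatter) from compound 1 to compound 2 and a 1.1-fold lower number (0.03 log units; within the scatter) from compound 3 to compound 4, 1.0-fold (0.01 log units) apart, within the scatter of two such steps. This shows that, across these two cores, the change leaves a step too small to separate from the scatter of repeated runs; it does not show that methyl and chloro are interchangeable on other cores, and steps this small cannot reveal whether a larger effect would carry from one core to another.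

All four compounds shown carry only methyl or chloro on this aromatic ring, which leaves open what an amine, a hydroxyl or a nitrile would do there. They also leave open how the series would respond if an amide or a carboxylic acid took the place of the ester groups on the shared scaffold.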